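The compounds below may be only part of what the source reports. "The series", "measured", "known", "first", "only" and "open" are said of these compounds alone.

Among the compounds with values here, in an ADME assay on HepG2 2.2.15 cells (Homo sapiens) for cytotoxicity, read by MTT assay, with stated times of 48 h and 9 days (on this read-out lower numbers stand for higher toxicity in this test and higher numbers for lower toxicity in this test), compound 2 `COc1ccc2c(=O)c(/C=C/C(=O)Nc3ccccc3Cl)coc2c1` gives 1010000 nM, the highest of the three numbers measured so far. Compound 1 `O=C(/C=C/c1coc2cc(O)ccc2c1=O)NCc1ccccc1` gives 436000 nM, and compound 3 `O=C(/C=C/c1coc2cc(O)ccc2c1=O)NCc1ccc(F)cc1` gives 357000 nM; compound 2 stands beyond the scatter from both, nearest to compound 1 and furthest from compound 3. Within the data shown here, the only measured step between two compounds that differ in one place runs a 1.2-fold lower number from compound 1 to compound 3 (0.09 log units; within the scatter), fluoro in place of hydrogen on an aromatic carbon, and it lies within the scatter.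

Compound 4 `COc1ccc2c(=O)c(/C=C/C(=O)Nc3ccccc3OC)coc2c1` differs from compound 2 by methoxy in place of chloro on an aromatic carbon, ortho to a large group, so that 2-chlorophenyl becomes 2-methoxyphenyl. Among the measured compounds shown here, no measured step exchanges one substituent for another on that ring; the change from compound 1 to compound 3 is the only comparison on the aromatic ring at the amide end, and it was small. On this footing there is no ground to expect a step in this assay beyond the scatter in either direction. Compound 4 is therefore estimated to give 900000 nM in this assay, within a range from 400000 nM to 2000000 nM. The expected step from compound 2 to compound 4 is a 1.1-fold lower number from compound 2 to compound 4 (0.05 log units; within the scatter), within the scatter.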

Compound 4, half-maximal cytotoxic concentration: 1050000 nM
Compound 4: the middle estimate sits 1.2-fold (0.07 log units) below what was measured, within the range that was stated.
By their numbers in this assay, from the lowest: compounds 3 and 1 (each within the scatter of the next); then compounds 2 and 4 (each within the scatter of the next).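

In this assay, methoxy in place of chloro on an aromatic carbon, ortho to a large group, comes to a 1.0-fold higher number from compound 2 to compound 4 (0.02 log units; within the scatter), so 2-chlorophenyl and 2-methoxyphenyl cannot be told apart on this read-out. The earlier step, a 1.2-fold lower number from compound 1 to compound 3 (0.09 log units; within the scatter), put fluoro in place of hydrogen on a different pair of compounds, whereas this one exchanges one substituent for another at this place, with the entering methoxy carrying a hydrogen-bond acceptor that the leaving chloro does not, and the step still lies within the scatter. Nothing available here offers an explanation for this outcome.

The compounds shown leave open whether the flat picture at this place extends to groups of another kind, such as an amine or a carboxylic acid, or to a longer chain such as ethoxy. They also leave open whether the same exchange of chloro for methoxy would read alike on the core of compound 1, or with the group at a different place on the ring.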